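A Methyl Added to the Ester Phenyl of Compound 3

This account rests on a few compounds, and the source may have more. Where it says the series, first, only, none or still open, it means among the compounds named here.

Three measured compounds:
compound 1, `CC(=O)c1cccc(NC(=O)Nc2ccc(OC(=O)c3cc4cc([N+](=O)[O-])ccc4s3)cc2)c1`, gives 61500 nM
compound 2, `COc1ccc(C(=O)Oc2ccc(NC(=O)Nc3ccc(Cl)c(C(F)(F)F)c3)cc2)cc1`, gives 16100 nM
compound 3, `O=C(Nc1ccccc1)Nc1ccc(OC(=O)c2ccccc2)cc1`, gives 81200 nM

All three numbers come from a functional assay on A549 cells (Homo sapiens) for antiproliferative activity, read by MTT assay, with a stated time of 48 h; on this read-out lower numbers stand for stronger inhibition and higher numbers for weaker inhibition. Compound 3 has the highest of the three numbers, which means the weakest inhibition measured so far. Its nearest neighbour is compound 1, whose number is within the usual scatter of that of compound 3, so the two cannot be told apart. Compound 2 is further away, with a number beyond the scatter from compound 3, and is therefore the only one of the three that clearly inhibits more strongly.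

Compound 4, `Cc1ccc(C(=O)Oc2ccc(NC(=O)Nc3ccccc3)cc2)cc1`, is not yet measured. It differs from compound 3 in one spot: methyl in place of hydrogen on an aromatic carbon. Going by the values given here, no pair of measured compounds differs by exactly this change, so there is no directly measured step to lean on. Compound 2 does carry a small group on the same ring, but it also carries a different substituted aryl at the other end, so its number cannot be attributed to either change alone.

Among the compounds with values here, with only a single small group added, the step from compound 3 to compound 4 is expected to be modest, most likely a small decrease in the number and possibly none beyond the scatter: a 1.6-fold lower number from compound 3 to compound 4 (0.21 log units; within the scatter). Compound 4 is therefore estimated at 50000 nM, with a plausible range from 15000 nM to 150000 nM.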

Compound 4, half-maximal inhibitory concentration: 18900 nM
Compound 4: the middle estimate sits 2.6-fold (0.42 log units) above what was measured, and the stated range covers the measured number.
By their numbers in this assay, from the lowest: compounds 2 and 4 (each within the scatter of the next); then compounds 1 and 3 (each within the scatter of the next).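

In this assay the change from phenyl to 4-methylphenyl gives a 4.3-fold lower number from compound 3 to compound 4 (0.63 log units; beyond the scatter) with only one carbon added, so a very small change at this position is enough to shift the number clearly. Going by these compounds alone, this is the first pair in the set that differs in a single place, which makes the effect of the methyl readable on its own; the earlier compounds differ from one another in more than one place, so they could not show what this position does. The methyl sits para to a large group on a six-membered aromatic ring of carbon only, and this spot is now known to respond to substitution, although no measurement at hand explains why the number falls.

From the compounds shown here alone, whether an ethyl group, an amine or a carboxylic acid in the same spot would lower the number further, leave it unchanged or raise it remains open. Also open, going by these compounds, is whether the methyl would produce a similar step in a compound carrying a different group at the other end of the molecule, as this single step rests on one pair.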